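Cytotoxicity notes: methoxy in place of amino

This account rests on a few compounds, and the source may have more. Where it says the series, first, only, none or still open, it means among the compounds named here.

Measured so far in an ADME assay on BHK cells (Mesocricetus auratus) for cytotoxicity, read by MTT assay, with a stated time of 96 h; a higher number here means that more compound is tolerated, a lower number that less compound is tolerated:
- compound 1 `COc1ccc(-c2nc3cc(C(F)(F)F)ccc3[nH]2)c(N)c1`: >= 100000 nM (a limit)
- compound 2 `Oc1ccc(-c2nc3cc(C(F)(F)F)ccc3[nH]2)cc1`: > 100000 nM (a limit)
- compound 3 `CCN(CC)CC(=O)Nc1ccc(-c2nc3cc(C(F)(F)F)ccc3[nH]2)cc1`: 23000 nM

Compound 1 stands at the upper edge of what this assay reports: for compound 1 the value >= 100000 nM is a limit of the assay, not a number, as noted in the limit of >= 100000 nM in this assay, at which 1 of the 3 values shown sits. Compound 2 likewise gives only a limit, > 100000 nM, as noted in the limit of > 100000 nM in this assay, at which 1 of the 3 values shown sits. Among the compounds with values here, compound 3 is the only compound with a number, 23000 nM. Within the data shown here, the single measured step is an at least 4.3-fold lower number from compound 2 to compound 3 (0.63 log units; beyond the scatter).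

Compound 4 `COc1ccc(-c2nc3cc(C(F)(F)F)ccc3[nH]2)c(OC)c1` differs from compound 1 as follows: methoxy in place of amino on an aromatic carbon. Among the measured compounds shown here, no measured step concerns this change; the step of an at least 4.3-fold lower number from compound 2 to compound 3 (0.63 log units; beyond the scatter) involves a different group entering in place of hydroxy and bears on it only loosely. For the measured compounds named here, with compound 1 at the limit and no step toward a lower number for this kind of change, no step beyond the scatter is expected in this assay; the estimate for compound 4 means a number no higher from compound 1 to compound 4 (the limit leaves the size open). Compound 4 is therefore expected near 100000 nM, within 40000 nM to 250000 nM, most likely reported again as a limit.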

Compound 4, half-maximal cytotoxic concentration: > 100000 nM
Compound 4 was reported as a limit (the forecaster's own chance of this, stated with the estimate: 70%); the middle value sits exactly at the limit.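

Compound 1 and compound 4 both give only a limit in this assay, so no step can be read for methoxy in place of amino on an aromatic carbon. The compounds shown leave open what number either compound would give and whether the two differ.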